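A few compounds are considered here, and "the series" means these few. Any claim that something is new, unique, unknown or untested is made for them only; others in the source may bear on it.

Measured compounds in an ADME assay on MT4 cells (Homo sapiens) for cytotoxicity, read by MTT assay, with a stated time of 5 days; a lower number here means that less compound is tolerated, a higher number that more compound is tolerated:

compound 1, `COc1cc2nc([S+]([O-])CC(=O)Nc3cccc([N+](=O)[O-])c3)nc(Nc3c(Cl)cc(/C=C/C#N)cc3Cl)c2cc1OC`: >= 83200 nM.
compound 2, `COc1cc2nc([S+]([O-])CC(=O)Nc3cccc(C(F)(F)F)c3)nc(Nc3c(Cl)cc(/C=C/C#N)cc3Cl)c2cc1OC`: 21800 nM.

Compound 1 gives only a limit of this assay, >= 83200 nM, and not a number. For the measured compounds named here, compound 2 is the only compound with a number in this assay, 21800 nM, so within the pair it is the one of which less is tolerated. Going by the values given here, the one measured step, an at least 3.8-fold lower number from compound 1 to compound 2 (0.58 log units; beyond the scatter), rests on the limit of >= 83200 nM in this assay, at which 1 of the 2 values shown sits, and is therefore known only as a minimum.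

Compound 3, `COc1cc2nc([S+]([O-])CC(=O)Nc3ccc(C)cc3)nc(Nc3c(Cl)cc(/C=C/C#N)cc3Cl)c2cc1OC`, has not yet been measured in this assay. Its change against compound 2 is 4-methylphenyl in place of 3-(trifluoromethyl)phenyl on an amide-type nitrogen. Among the compounds with values here, no measured step concerns this change: the step from compound 1 to compound 2 swaps nitro for trifluoromethyl on an aromatic carbon, and it gives no guide to the exchange of 3-(trifluoromethyl)phenyl for 4-methylphenyl on the amide-type nitrogen. With nothing to point either way, the step expected in this assay is a 1.4-fold higher number from compound 2 to compound 3 (0.14 log units; within the scatter), within the usual scatter or at most modest. Compound 3 is therefore estimated at 30000 nM, in a range from 12000 nM to 80000 nM.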

Compound 3, half-maximal cytotoxic concentration: 32200 nM
Compound 3: middle estimate off by 1.1-fold (0.03 log units), on the low side, within the range that was stated.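

In this assay, exchanging 3-(trifluoromethyl)phenyl for 4-methylphenyl on the amide-type nitrogen gives a 1.5-fold higher number from compound 2 to compound 3 (0.17 log units; within the scatter), so this position takes a second aryl group without a change that can be told from the scatter, even though the substituent and its place on the ring differ at once. The other new step, an at least 2.5-fold lower number from compound 1 to compound 3 (0.41 log units; beyond the scatter), sets the 3-nitrophenyl group apart from 4-methylphenyl as well as from 3-(trifluoromethyl)phenyl, but its size is only a minimum: the limit of >= 83200 nM in this assay, at which 1 of the 3 values shown sits. For the compounds shown here, compound 2 and compound 3 thus sit together in this assay, and compound 1 is the one compound that goes against this grouping, so the separation now seen with two different groups points to something about the 3-nitrophenyl compound rather than to a feature of compound 2 alone.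

Going by these compounds alone, the single exchange does not show whether the substituent or its place on the ring matters more, and how far compound 1 really lies from the other two stays unknown. Also open, going by these compounds, is whether an amine or a carboxylic acid on the phenyl ring, or a longer alkyl chain in place of that ring on the amide-type nitrogen, would stay level with compound 2 and compound 3.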